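Extending a Methoxy Group: Compound 3 to Compound 4

This account rests on a few compounds, and the source may have more. Where it says the series, first, only, none or still open, it means among the compounds named here.

Compound 3 `COc1cc(/C=C2\CCC/C(=C\c3cccc([N+](=O)[O-])c3)C2=O)cc(Br)c1OC` gives 16.7 ug/mL in a functional assay on SK-N-MC cells (Homo sapiens) for cytotoxicity, read by MTT assay (on this read-out lower numbers stand for stronger inhibition and higher numbers for weaker inhibition), the highest of the three numbers shown. Compound 2 `COc1ccc(/C=C2\CCC/C(=C\c3cccc([N+](=O)[O-])c3)C2=O)cc1` gives 10.4 ug/mL, a number within the scatter of compound 3, whereas compound 1 `COc1cc(/C=C2\CCC/C(=C\c3ccccc3[N+](=O)[O-])C2=O)cc(Br)c1OC` gives 6.24 ug/mL, a number beyond the scatter. For the measured compounds named here, the only measured step, a 2.7-fold higher number from compound 1 to compound 3 (0.43 log units; beyond the scatter), concerns the position of the nitro group on the pendant phenyl ring and so does not bear on the change that leads to compound 4 `CCOc1c(Br)cc(/C=C2\CCC/C(=C\c3cccc([N+](=O)[O-])c3)C2=O)cc1OC`, namely (methyl in place of hydrogen on a saturated chain carbon bound to an oxygen on an aromatic ring). Going by the values given here, with no measured pair speaking to such a change, the step of no change at the digits printed from compound 3 to compound 4 (within the scatter) is expected to remain within the scatter. Compound 4 is therefore estimated at 16.7 ug/mL, with a range from 8 ug/mL to 35 ug/mL.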

Compound 4, half-maximal inhibitory concentration: 10.8 ug/mL
Compound 4: middle estimate off by 1.5-fold (0.19 log units), on the high side; low and high end bracket the measured number.
By their numbers in this assay, from the lowest: compounds 1, 2, 4 and 3 (each within the scatter of the next, the first and the last beyond it).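

In this assay, the change from methoxy to ethoxy gives a 1.5-fold lower number from compound 3 to compound 4 (0.19 log units; within the scatter), so this methyl on a saturated chain carbon bound to an oxygen on an aromatic ring brings no step beyond the scatter. For the compounds shown here, this is the first measured pair at this position, since the only earlier step concerned the nitro group. No evidence is available to explain this result. On these data alone, whether a longer chain such as propoxy, or an amine in place of the ethoxy, would give a step beyond the scatter remains open.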